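Notes on aryl-ether variation of the shared core

This account rests on a few compounds, and the source may have more. Where it says the series, first, only, none or still open, it means among the compounds named here.

Measured so far in an assay on CHO cells for binding affinity to metabotropic glutamate receptor 2 (Rattus norvegicus); on this read-out higher numbers stand for weaker inhibition and lower numbers for stronger inhibition:
- compound 1 `N[C@]1(C(=O)O)[C@H]2[C@@H](C[C@H]1OCCCc1ccccc1)[C@]2(F)C(=O)O`: 9.83 nM
- compound 2 `N[C@]1(C(=O)O)[C@H]2[C@@H](C[C@H]1OCc1cccc(Br)c1)[C@]2(F)C(=O)O`: 4.71 nM
- compound 3 `N[C@]1(C(=O)O)[C@H]2[C@@H](C[C@H]1OCc1ccc(-c3ccccc3)cc1)[C@]2(F)C(=O)O`: 25.6 nM

Compound 2 gives the lowest number of the three in this assay; compound 1 sits nearest, and the gap is a 2.1-fold lower number from compound 1 to compound 2 (0.32 log units; beyond the scatter). Compound 3, with the biphenyl ether, gives the highest number of the set.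

Compound 4 `Nc1cccc(CO[C@@H]2C[C@@H]3[C@H]([C@]2(N)C(=O)O)[C@@]3(F)C(=O)O)c1` is the next step from compound 2: amino in place of bromo on an aromatic carbon. The change keeps the ring and the meta substitution; it swaps bromo for amino, which brings in one hydrogen-bond donor and one acceptor where the bromo had none.

Among the compounds with values here, no measured step in the set exchanges one substituent for another on the aromatic ring; the only single-point step, from compound 1 to compound 2, swaps the whole pendant group and is modest in size. The set therefore gives no direct guide for bromo to amino. Taking the modest spread among the three ethers as the reference, a step in this assay of modest size is expected for compound 4, more likely toward a higher number than a lower one, and possibly within the scatter.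

The estimate for compound 4 is 10 nM, with a range from 3.5 nM to 30 nM, which corresponds to an expected step of a 2.1-fold higher number from compound 2 to compound 4 (0.33 log units; beyond the scatter).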

Compound 4, inhibition constant: 15.4 nM
Estimate against measurement, compound 4: 1.5-fold (0.19 log units) below, and the stated range covers the measured number.
By their numbers in this assay, from the lowest: compound 2; then compounds 1, 4 and 3 (each within the scatter of the next, the first and the last beyond it).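

Within the data shown here, this is the first exchange on the aromatic ring itself, and in this assay amino in place of bromo, meta to a large group, gives a 3.3-fold higher number from compound 2 to compound 4 (0.51 log units; beyond the scatter), so this place responds to a change of one substituent. Set against the phenethyl ether, the 3-aminophenyl ether gives a 1.6-fold higher number from compound 1 to compound 4 (0.19 log units; within the scatter), so the advantage of 3-bromophenyl over phenethyl does not carry over to 3-aminophenyl. No evidence on the origin of the step from bromo to amino is available.

As far as these compounds go, it remains open whether bromo is unusually favourable here or amino is unfavourable, a question that chloro, methyl or hydroxyl at the same place could help settle. From the compounds shown here alone, it is also open whether the same exchange would have a similar effect with the substituent elsewhere on the ring or on the biphenyl ether.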